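The source may report more compounds than this note shows. Statements on the series, on what has been measured and on what is new or still open speak of the compounds shown alone.

- Compound 1 `CNC(=O)c1cc(C(=O)N[C@H]2[C@@H]3C[C@H](O)C[C@@H]32)cc2c1OC[C@@]2(C)c1ccccc1`: >= 151 ug/mL
- Compound 2 `CNC(=O)c1cc(C(N)=O)cc2c1OC[C@H]2c1ccccc1`: >= 144 ug/mL
- Compound 3 `CNC(=O)c1cc(C(N)=O)cc2c1O[C@H](CF)[C@H]2c1ccccc1`: >= 128 ug/mL

All three compounds were tested in a physicochemical assay for solubility (on this read-out lower numbers stand for lower solubility and higher numbers for higher solubility), and each result is a limit rather than an exact number. Compound 3 therefore has no exact position, only its limit of >= 128 ug/mL.

Compound 4 `CNC(=O)c1cc(C(=O)NCCC[C@H]2OC[C@H](N)CO2)cc2c1O[C@H](CF)[C@H]2c1ccccc1` keeps the structure of compound 3 apart from one change: a group of 10 heavy atoms (7 carbon, 1 nitrogen, 2 oxygen; one six-membered non-aromatic ring with 2 hetero atoms) in place of a hydrogen atom, on an amide-type nitrogen. The amide hydrogen is replaced by a group containing a six-membered non-aromatic ring with 2 hetero atoms.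

Among the compounds with values here, the only measured step offers little guidance: a step that the two limits leave unreadable from compound 2 to compound 3. Its size cannot be read, and it involves a different part of the molecule. Compound 1 gives a closer hint, since it also carries a group on an amide-type nitrogen. Its result of >= 151 ug/mL is likewise a limit.

On this slim evidence, no step beyond the usual scatter is expected in this assay, and another limit is the most likely report. The estimated change is a step that the limit leaves unreadable from compound 3 to compound 4. Compound 4 is expected to read about 170 ug/mL, within an estimated range of 105 ug/mL to 235 ug/mL.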

Compound 4, solubility: 174 ug/mL
Compound 4: middle estimate off by 1.0-fold (0.01 log units), on the low side; measured number inside the range.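

No step can be read from compound 3 to compound 4, because the result for compound 3 is only a limit: the limit of >= 128 ug/mL in this assay, at which 1 of the 4 values shown sits. The compounds shown leave open how far, and in which direction, the reading moves when this group replaces the amide hydrogen.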